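A Pyridyl Swap in a Potassium Channel Inhibitor Series

The source may hold more compounds than are shown below. What is called first, only, known or untested is meant among the compounds shown, and "the series" means these compounds.

Measured so far:
Compound 1 `C[C@H](NC(=O)c1cc(C2CC2)nn1C)c1nc(-c2ccccc2)no1`: 11400 nM
Compound 2 `Cc1cccc(-c2nnc([C@H](C)NC(=O)c3cc(C4CC4)nn3C)o2)c1`: > 30000 nM
Compound 3 `Cc1cncc(-c2noc([C@H](C)NC(=O)c3cc(C(F)(F)F)nn3C)n2)c1`: 1370 nM

In an assay on T-REx-293 cells for inhibition of potassium channel subfamily T member 1 (Homo sapiens), read by patch clamp (a higher number here means a weaker inhibitor, a lower number a stronger inhibitor), compound 3 gives 1370 nM, the lowest of the two numbers recorded. Compound 1, by comparison, gives 11400 nM, a difference that lies beyond the usual scatter. For compound 2 the assay reports only a limit rather than a number, namely > 30000 nM, which is the limit of > 30000 nM in this assay, at which 1 of the 3 values shown sits.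

Compound 4 `CNc1cc(-c2noc([C@H](C)NC(=O)c3cc(C(F)(F)F)nn3C)n2)ccn1` has not yet been measured in this assay. It differs from compound 3 in one place: 2-(methylamino)pyridin-4-yl in place of 5-methylpyridin-3-yl on an aromatic carbon. Within the data shown here, no measured pair among the three compounds isolates a change of this kind, so there is no direct precedent for the size of the step. Given that compound 3 already holds the best number with 1370 nM, the change is expected to move the value only modestly, perhaps a small improvement, with a step of a 1.4-fold lower number from compound 3 to compound 4 (0.14 log units; within the scatter) estimated. On that basis compound 4 is estimated at 1000 nM, within a range from 300 nM to 4000 nM.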

Compound 4, half-maximal inhibitory concentration: 195 nM
Compound 4: middle estimate off by 5.1-fold (0.71 log units), on the high side, and the stated range ends above it.
By their numbers in this assay, from the lowest: compound 4; then compound 3; then compound 1. At a limit, above all of these: compound 2.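

Among these compounds, this is the first comparison that changes one place only, and in this assay it gives a 7.0-fold lower number from compound 3 to compound 4 (0.85 log units; beyond the scatter). The aromatic carbon between two ring nitrogen atoms is therefore a place where the choice of pyridine group alone moves the value beyond the scatter, with the rest of the molecule held the same. The swap brings in a hydrogen-bond donor that 5-methylpyridin-3-yl lacks, but it also moves the ring nitrogen and replaces the methyl group, so this single step cannot separate these changes.

The compounds shown leave open what a primary amine, a dimethylamino group or a methoxy group on the same pyridine ring would give. Nothing measured here bears on why the step has this size.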